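Phenyl to methoxy at the limit of the assay

The source may report more compounds than this note shows. Statements on the series, on what has been measured and on what is new or still open speak of the compounds shown alone.

Measured so far in an ADME assay on HEK293 cells (Homo sapiens) for cytotoxicity, read by luminescence, with a stated time of 72 h; a lower number here means that less compound is needed, a higher number that more compound is needed for the effect:
- compound 1 `CCOC(=O)c1c(-c2cccc(OC)c2)[nH]c2cc(OC)ccc2c1=O` gives > 22000 nM as a limit
- compound 2 `CCOC(=O)c1c(-c2cccc(-c3ccccc3)c2)[nH]c2cc(OC(C)C)ccc2c1=O` gives > 22000 nM as a limit

Compound 2 has no number, only a limit (> 22000 nM). The whole record is the limit of > 22000 nM in this assay, at which 2 of the 2 values shown sit, and nothing more. Compound 3 `CCOC(=O)c1c(-c2cccc(OC)c2)[nH]c2cc(OC(C)C)ccc2c1=O` carries methoxy in place of phenyl on an aromatic carbon, meta to a large group (methoxy in place of phenyl on an aromatic carbon). Among the measured compounds shown here, no measured step covers this change, so in this assay no step beyond the scatter is expected, resting only on compound 2 and its limit (> 22000 nM). The expected change is a number no higher from compound 2 to compound 3 (the limit leaves the size open) and remains an estimate. For compound 3 the estimated value is 22000 nM, with a range from 14000 nM to 32000 nM, and a report as a limit is expected.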

Compound 3, half-maximal effective concentration: > 22000 nM
Compound 3 ended at the assay's limit (the forecaster's own chance of this, stated with the estimate: 90%); the middle value sits exactly at the limit.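

In this assay compound 3 gives > 22000 nM, a limit. No step from compound 1 or compound 2 to compound 3 can be read, and the record stays at one point: the limit of > 22000 nM in this assay, at which 3 of the 3 values shown sit.

The compounds shown leave open at what concentration, if any, each would reach the half-maximal effect, and whether either exchange shifts it.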